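A few compounds are considered here, and "the series" means these few. Any claim that something is new, unique, unknown or untested is made for them only; others in the source may bear on it.

Measured so far:
- compound 1, `Cc1nc(CN2CCCC2c2ccccn2)cc(N2CCN(C)CC2)n1`: 319 nM
- compound 2, `Cc1ccnc([C@@H]2CCCN2Cc2cc(N3CCN(C)CC3)nc(C)n2)c1`: 216 nM

Both numbers come from an assay on HPBALL cells for binding affinity to C-X-C chemokine receptor type 4 (Homo sapiens), read by flow cytometry, with a stated time of 3 h; on this read-out lower numbers stand for stronger inhibition and higher numbers for weaker inhibition. Compound 2 gives the lower of the two, but the gap to compound 1 lies within the scatter of this assay, so the two compounds cannot be told apart on the numbers shown, and compound 1 differs from compound 2 in more than one place, so no step is drawn between them.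

The next compound, compound 3, `Cc1cccc([C@@H]2CCCN2Cc2cc(N3CCN(C)CC3)nc(C)n2)n1`, keeps the whole of compound 2 except for one change: 6-methylpyridin-2-yl in place of 4-methylpyridin-2-yl on a saturated ring carbon. The same atoms are present, joined differently; only the position of the methyl on the pyridine ring moves.

Among the measured compounds shown here, nothing measured in this assay separates a 4-methyl from a 6-methyl on this ring, and the only comparison available, compound 1 against compound 2, shows no resolvable effect of the methyl at all. The step from compound 2 to compound 3 is therefore expected to be a 1.2-fold higher number from compound 2 to compound 3 (0.06 log units; within the scatter), that is, none beyond the scatter, with no preferred direction. For compound 3 in this assay a value of 250 nM is estimated, with a range from 80 nM to 800 nM.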

Compound 3, half-maximal inhibitory concentration: 2390 nM
The estimate for compound 3 lay 9.6-fold (0.98 log units) below the measured number, and the stated range ends below it.
By their numbers in this assay, from the lowest: compounds 2 and 1 (each within the scatter of the next); then compound 3.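

Moving the methyl on the pyridine ring gives an 11-fold higher number from compound 2 to compound 3 (1.04 log units; beyond the scatter) in this assay and this is the first change in the series that can be read beyond the scatter. The group that leaves and the group that enters have the same heavy atoms, ring type and hydrogen-bond counts, so these counts do not separate 4-methylpyridin-2-yl from 6-methylpyridin-2-yl, whereas the read-out does. On this saturated ring carbon, the placement of a single methyl on the pyridine is therefore enough to change the result markedly, which the earlier pair of compounds could not show, as they differ in more than one place. No measurement shown here accounts for the difference.

Compound 2 and compound 3 alone do not show whether the higher number belongs to the methyl specifically or would also follow another group at the same ring position, such as the ethyl of 6-ethylpyridin-2-yl or the amine of 6-aminopyridin-2-yl. From the compounds shown here alone, it also remains open where 5-methylpyridin-2-yl would fall, and whether the unsubstituted pyridin-2-yl would stand with compound 2 or compound 3 on an otherwise identical scaffold.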